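The source may report more compounds than this note shows. Statements on the series, on what has been measured and on what is new or still open speak of the compounds shown alone.

Compound 2 `CC1CCN(c2nc(C(F)(F)F)ccc2CNC(=O)Nc2ccc3cnncc3c2)CC1` gives 8.9 nM in an assay on isolated protein for antagonist activity at transient receptor potential cation channel subfamily V member 1 (Homo sapiens), read by FLIPR (a lower number here means a stronger inhibitor, a higher number a weaker inhibitor), and compound 1 `CC(C)(C)c1ccc(CNC(=O)Nc2cccc3cnccc23)cc1` gives 13.8 nM in this assay; the two numbers lie within the scatter of each other, so neither stands apart. Compound 3 `CC1CCN(c2nc(C(F)(F)F)ccc2CNC(=O)Nc2nccc3cccnc23)CC1` has not yet been measured in this assay. Its difference from compound 2 is a group of 10 heavy atoms (8 carbon, 2 nitrogen; 2 six-membered aromatic rings with 1 hetero atom each) in place of a group of 10 heavy atoms (8 carbon, 2 nitrogen; one six-membered aromatic ring of carbon only, one six-membered aromatic ring with 2 hetero atoms), on an amide-type nitrogen. For the measured compounds named here, no measured pair shows what such a change does here, so the step is expected to be small, most likely none beyond the scatter, with at most a slight weakening: a 1.7-fold higher number from compound 2 to compound 3 (0.23 log units; within the scatter). Compound 3 is therefore estimated at 15 nM in this assay, within a range from 3 nM to 70 nM.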

Compound 3, inhibition constant: "not active" (no number reported)
No number was reported for compound 3; no gap can be computed for the estimate.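

For the compounds shown here, compound 3 is reported only as "not active", with no number, so no step from compound 2 to compound 3 can be read. The compounds shown leave open how much weaker compound 3 is, if it has any measurable activity at all. Nothing shown explains this result.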